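A few compounds are considered here, and "the series" means these few. Any claim that something is new, unique, unknown or untested is made for them only; others in the source may bear on it.

Compound 1 `COc1cc(NC(=O)c2ccc(C)c(C#Cc3cc(-c4cnn(C)c4)cnc3N)c2)cc(OC)c1` gives 397 nM in an ADME assay on RBL-2H3 cells (Rattus norvegicus) for cytotoxicity, read by CCK-8 assay, with a stated time of 24 h; a lower number here means that less compound is tolerated, a higher number that more compound is tolerated. Compound 2 `Cc1ccc(C(=O)Nc2cccc(Cl)c2)cc1C#Cc1cc(-c2cnn(C)c2)cnc1N` gives 24.8 nM in this assay. Compound 3 `Cc1ccc(C(=O)Nc2ccc(Cl)cc2)cc1C#Cc1cc(-c2cnn(C)c2)cnc1N` gives 269 nM in this assay.

Compound 3 holds the second highest of the three numbers: compound 1 is close to it, as a 1.5-fold lower number from compound 1 to compound 3 (0.17 log units; within the scatter) shows, while compound 2 lies far from it, as an 11-fold higher number from compound 2 to compound 3 (1.04 log units; beyond the scatter) shows. Compound 4 `Cc1ccc(C(=O)Nc2cccc(C(F)(F)F)c2)cc1C#Cc1cc(-c2cnn(C)c2)cnc1N` differs from compound 3 in one place: 3-(trifluoromethyl)phenyl in place of 4-chlorophenyl on an amide-type nitrogen. The step that bears on this is an 11-fold higher number from compound 2 to compound 3 (1.04 log units; beyond the scatter), a large one, where 3-chlorophenyl went with a much lower number than 4-chlorophenyl; the entering 3-(trifluoromethyl)phenyl is named in the same way as that 3-chlorophenyl. A lower number is therefore expected for compound 4, a step of a 5.4-fold lower number from compound 3 to compound 4 (0.73 log units; beyond the scatter), giving an estimate of 50 nM with a range from 15 nM to 200 nM.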

Compound 4, half-maximal cytotoxic concentration: 7 nM
Compound 4: middle estimate off by 7.1-fold (0.85 log units), on the high side; the whole stated range lies above it.
By their numbers in this assay, from the lowest: compound 4; then compound 2; then compounds 3 and 1 (each within the scatter of the next).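

On the amide-type nitrogen, the group can push the number in this assay lower than either chlorophenyl compound did, with a 38-fold lower number from compound 3 to compound 4 (1.58 log units; beyond the scatter) and a 57-fold lower number from compound 1 to compound 4 (1.75 log units; beyond the scatter) leaving compound 4 lowest of the four. Even the smaller change from 3-chlorophenyl to 3-(trifluoromethyl)phenyl counts, as trifluoromethyl in place of chloro gives a 3.5-fold lower number from compound 2 to compound 4 (0.55 log units; beyond the scatter) and so the group itself matters, not only its place on the ring. Nothing available explains these steps. Still open, as far as these compounds go, is how a phenyl ring carrying an amine or a carboxylic acid would behave here.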